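Dichlorophenyl for methoxyphenyl on the thioether chain

The source may hold more compounds than are shown below. What is called first, only, known or untested is meant among the compounds shown, and "the series" means these compounds.

Of the compounds shown here, two have been measured in an assay on isolated protein for inhibition of Amine oxidase [flavin-containing] B (Homo sapiens); a lower number here means a stronger inhibitor, a higher number a weaker inhibitor. Compound 1 `C#CCNC1CCc2c(SCCc3cccc(C)c3)cccc21` gives 0.35 nM. Going by the values given here, compound 2 `C#CCNC1CCc2c(SCCc3ccc(OC)cc3)cccc21` gives 62000 nM, the highest of the two numbers; its only neighbour is compound 1, with a 180000-fold higher number from compound 1 to compound 2 (5.25 log units; beyond the scatter). Compound 3 `C#CCNC1CCc2c(SCCc3ccc(Cl)c(Cl)c3)cccc21` is not yet measured. It differs from compound 2 by 3,4-dichlorophenyl in place of 4-methoxyphenyl on a saturated chain carbon, two bonds along the chain from a sulfur. Among the compounds with values here, the one measured step that bears on this change is a 180000-fold higher number from compound 1 to compound 2 (5.25 log units; beyond the scatter), which shows how strongly the number moved when 4-methoxyphenyl entered this position. Removing the 4-methoxyphenyl again is therefore expected to bring a large fall in this assay, though how far 3,4-dichlorophenyl resembles 3-methylphenyl here is not known from the two measured compounds. Compound 3 is estimated at 30 nM, within 0.5 nM to 3000 nM, an expected step of a 2100-fold lower number from compound 2 to compound 3 (3.32 log units; beyond the scatter).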

Compound 3, half-maximal inhibitory concentration: 3850 nM
For compound 3 the middle estimate is 130-fold (2.11 log units) below the measured one; measured number outside the range, above it.
By their numbers in this assay, from the lowest: compound 1; then compound 3; then compound 2.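

In this assay, 3,4-dichlorophenyl recovers only a small part of what was lost with 4-methoxyphenyl (a 16-fold lower number from compound 2 to compound 3 (1.21 log units; beyond the scatter)), and a very large gap to the 3-methylphenyl of compound 1 remains (an 11000-fold higher number from compound 1 to compound 3 (4.04 log units; beyond the scatter)). Taking away 4-methoxyphenyl is therefore not enough on its own to restore the number of compound 1, and this position, on a saturated chain carbon two bonds along the chain from a sulfur, now shows an intermediate result as well as the two extremes. Nothing measured here explains this order.

Going by these compounds, it remains open whether the low number of compound 1 depends on the methyl group itself or on its place on the ring, and whether compound 3 owes its number to one chlorine or to both. A plain phenyl or a 3-chlorophenyl group on the same chain would bear on both questions.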